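The source may hold more compounds than are shown below. What is called first, only, known or untested is meant among the compounds shown, and "the series" means these compounds.

Working notes on the series. In an ADME assay on MDCK-II cells (Canis lupus familiaris) for cytotoxicity, read by MTT assay, with a stated time of 72 h (a lower number here means a stronger inhibitor of growth, a higher number a weaker inhibitor of growth), compound 1 `COc1ccc(/C=C/C(=O)c2cccc(Nc3ncnc4ccccc34)c2)cc1OC` gives 3420 nM and compound 2 `COc1ccc(/C=C/C(=O)c2cccc(Nc3ncnc4cc(OC)c(OC)cc34)c2)cc1OC` gives 6140 nM. Among the measured compounds shown here, compound 2 therefore stands within the scatter of compound 1, the only other measured compound, and the two values cannot be told apart.

Compound 3 `COc1ccc(/C=C/C(=O)c2cccc(Nc3ncnc4cc(OC)c(OC)cc34)c2)cc1` follows from compound 2 by one change, 3,4-dimethoxyphenyl to 4-methoxyphenyl: hydrogen in place of methoxy on an aromatic carbon. In words, this is hydrogen in place of methoxy on an aromatic carbon.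

For the measured compounds named here, no measured pair shows this change, so the data offer no direct precedent for its size or direction. The expectation in this assay is therefore no shift beyond the scatter, with the direction left open. The estimated step of a 1.2-fold lower number from compound 2 to compound 3 (0.09 log units; within the scatter) is expected to stay within that scatter. For compound 3 the estimated value is 5000 nM, with an expected range of 2000 nM to 12000 nM.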

Compound 3, concentration for 50% growth inhibition: 16900 nM
Beside the measured number, compound 3's estimate is 3.4-fold (0.53 log units) below it, outside the stated range (above it).
By their numbers in this assay, from the lowest: compounds 1 and 2 (each within the scatter of the next); then compound 3.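

In this assay, among the compounds shown here, hydrogen in place of methoxy on an aromatic carbon gives a 2.8-fold higher number from compound 2 to compound 3 (0.44 log units; beyond the scatter), the first step that lies beyond the scatter, which shows that the 3,4-dimethoxyphenyl group is not indifferent to this change. The step is modest, and its direction ties the methoxy group that leaves, ortho to a methoxy group, to the lower number in this single pair. Nothing available on the series accounts for this shift.

Only methoxy and hydrogen are shown at this position, so it remains open whether a hydroxyl, a fluorine or an amine there would track compound 2 or compound 3. Also open, on these data alone, is whether the same change, made on compound 1, would give a step of similar size and direction.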